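The source may hold more compounds than are shown below. What is called first, only, known or untested is meant among the compounds shown, and "the series" means these compounds.

Compound 1, `C/C(=C\Cc1c(O)ccc2c1O[C@H](c1ccc(O)cc1)CC2=O)C/C=C/C(C)(C)O`, carries a hydroxylated side chain on a shared flavanone-type core. In a functional assay on KB cells (Homo sapiens) for cytotoxicity, read by MTT assay (a higher number here means a weaker inhibitor, a lower number a stronger inhibitor), compound 1 gives > 10000 nM, which is a limit of the assay rather than a measured number. Compound 2, `COC(C)(C)/C=C/C/C(C)=C/Cc1c(O)ccc2c1O[C@H](c1ccc(O)cc1)CC2=O`, differs from it by one small change. In this assay compound 2 also gives > 10000 nM, again only a limit. For the measured compounds named here, the single measured step, a step that the two limits leave unreadable from compound 1 to compound 2, therefore cannot be sized, since the limit of > 10000 nM in this assay, at which 2 of the 2 values shown sit, describes both values. The unmeasured compound 3, `C=C(C)C(O)CC/C(C)=C/Cc1c(O)ccc2c1O[C@H](c1ccc(O)cc1)CC2=O`, is reached from compound 2 through (2-hydroxy-3-methylbut-3-en-1-yl in place of 3-methoxy-3-methylbut-1-en-1-yl on a saturated chain carbon bound to a double-bonded chain carbon). Going by the values given here, no measured step bears directly on this change; the one step that exists between the measured compounds is unreadable. Both measured compounds sit at the same limit, and nothing in the shown numbers suggests that a change to the side chain of this kind moves the compound into the measurable range. The expectation is that compound 3 will behave much like compound 2, with a step that the limit leaves unreadable from compound 2 to compound 3 that is not readable. Compound 3 is therefore estimated at 15000 nM, within a range from 4000 nM to 60000 nM, most likely reported again as a limit.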

Compound 3, half-maximal inhibitory concentration: > 10000 nM
Compound 3 gave a limit, no number (the forecaster's own chance of this, stated with the estimate: 80%); the middle value lies beyond the limit too.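

Compound 3 gives > 10000 nM in this assay and this is a limit, not a number. The steps linking compound 3 to compound 1 and compound 2 therefore cannot be read: the limit of > 10000 nM in this assay, at which 3 of the 3 values shown sit. From the compounds shown here alone, what stays open is whether any side chain on the shared core gives a value in this assay that is an actual number.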